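Piperazine-linked aminothiophene series: aryl exchange on the ring nitrogen

This account rests on a few compounds, and the source may have more. Where it says the series, first, only, none or still open, it means among the compounds named here.

Measured so far:
compound 1, `Nc1scc(CN2CCN(C3CCCCCC3)CC2)c1C(=O)c1ccc(Cl)cc1`: -25%
compound 2, `Nc1scc(CN2CCN(c3cc(F)ccc3F)CC2)c1C(=O)c1ccc(Cl)cc1`: -80%

In a functional assay on CHO cells with adenosine receptor A1 (Homo sapiens) as the target, read by cAMP accumulation and immunoassay, with a stated time of 6 min, tested at 10 uM (on this read-out lower numbers stand for a stronger effect and higher numbers for a weaker effect at the one concentration tested), compound 2 gives -80%, the lowest of the two numbers; the nearest is compound 1 with -25%, a gap beyond the scatter. Compound 3, `Nc1scc(CN2CCN(c3ccc(Cl)c(Cl)c3)CC2)c1C(=O)c1ccc(Cl)cc1`, has not been measured. It differs from compound 2 in one place: 3,4-dichlorophenyl in place of 2,5-difluorophenyl on an amine nitrogen in a ring.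

Among the compounds with values here, only one step is on record, a number 55 percentage points lower from compound 1 to compound 2 (beyond the scatter), where 2,5-difluorophenyl replaced cycloheptyl on the amine nitrogen in the ring. That step shows an aromatic group on this nitrogen giving a far stronger effect than cycloheptyl, but it does not compare one aromatic group with another. Within the data shown here, no measured pair tells how 3,4-dichlorophenyl fares against 2,5-difluorophenyl at this position. With the aromatic ring retained, the expectation is a step from compound 2 to compound 3 that stays within the scatter, a number 5 percentage points higher from compound 2 to compound 3 (within the scatter), with a wide range to reflect the lack of a direct precedent. Compound 3 is therefore expected to give about -75%, estimated between -95% and -45%.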

Compound 3, a percentage reported as activity, at one concentration (the size of the read-out at that concentration, not a potency): -62%
The estimate for compound 3 lay 13 percentage points below the measured number; low and high end bracket the measured number.
By their numbers in this assay, from the lowest: compound 2; then compound 3; then compound 1.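

In this assay, one aromatic group cannot simply be exchanged for another on this amine nitrogen: a number 18 percentage points higher from compound 2 to compound 3 (beyond the scatter), so 2,5-difluorophenyl gives the stronger effect of the two, even though both groups have the same count of heavy atoms and one six-membered aromatic ring of carbon only. The advantage over cycloheptyl survives the exchange, with a number 37 percentage points lower from compound 1 to compound 3 (beyond the scatter), so it now rests on two different aromatic groups rather than one. Nothing available explains the difference between the two halogen-bearing phenyl groups.

The two aromatic groups differ both in the halogen and in its placement on the ring, so the compounds shown cannot separate these two changes, which 2,5-dichlorophenyl or 3,4-difluorophenyl on the same nitrogen would begin to do. Also open, as far as these compounds go, is whether the halogens are needed at all, a question that unsubstituted phenyl at this position would address.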